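The source may report more compounds than this note shows. Statements on the series, on what has been measured and on what is new or still open speak of the compounds shown alone.

Compound 1, `Cc1ccc(-c2nc3ccccc3s2)cc1NC(=O)c1cc([N+](=O)[O-])c(N2CCCCC2)cc1Cl`, gives only an assay limit in an ADME assay on HepG2 cells (Homo sapiens) for cytotoxicity, with a stated time of 72 h; a higher number here means that more compound is needed for the effect, a lower number that less compound is needed: > 25000 nM.
Compound 2, `O=C(Nc1cc(-c2nc3ccccc3o2)ccc1F)c1cc([N+](=O)[O-])ccc1Cl`, likewise reaches only a limit in this assay: > 25000 nM.
Compound 3, `Cc1ccc(-c2nc3ccccc3s2)cc1NC(=O)c1cc([N+](=O)[O-])c(N2CCC(C(=O)O)CC2)cc1Cl`, also stops at a limit in this assay: > 25000 nM.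

Compound 3 thus stands at the limit of > 25000 nM in this assay, at which 3 of the 3 values shown sit, where every value shown rests; no number separates it from the other two. Compound 4, `Cc1ccc(-c2nc3ccccc3s2)cc1NC(=O)c1cc([N+](=O)[O-])c(N(C)C)cc1Cl`, differs from it in one place: dimethylamino in place of 4-carboxypiperidin-1-yl on an aromatic carbon. Within the data shown here, the single measured step that bears on this change is a step that the two limits leave unreadable from compound 1 to compound 3, and since both of its ends are limits its size cannot be read. Among the measured compounds shown here, nothing among the measured compounds points to a step in either direction, so the expected step that the limit leaves unreadable from compound 3 to compound 4 is taken as none beyond the scatter. Compound 4 is therefore estimated at 40000 nM, within 15000 nM to 120000 nM, most likely reported again as a limit.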

Compound 4, half-maximal effective concentration: > 25000 nM
Compound 4: no number, only a limit (the forecaster's own chance of this, stated with the estimate: 80%); the middle value is on the limit's open side.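

Compound 4 again gives only a limit in this assay, so its steps from compound 1 and compound 3 cannot be read: the limit of > 25000 nM in this assay, at which 4 of the 4 values shown sit.

The compounds shown leave open at what concentration any of them would reach the effect, and so whether these group changes matter at all.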